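Swapping hydroxy and methoxy on a dicoumarol-type inhibitor

This account rests on a few compounds, and the source may have more. Where it says the series, first, only, none or still open, it means among the compounds named here.

Measured compounds:
compound 1 `COc1cc(C(c2c(O)c3cc(C)ccc3oc2=O)c2c(O)c3cc(C)ccc3oc2=O)cc(OC)c1OC`, 386000 nM
compound 2 `COc1ccc(C(c2c(O)c3cc(C)ccc3oc2=O)c2c(O)c3cc(C)ccc3oc2=O)cc1`, 107000 nM
compound 3 `COc1ccc(C(c2c(O)c3cc(Cl)ccc3oc2=O)c2c(O)c3cc(Cl)ccc3oc2=O)cc1O`, 113000 nM

In an assay on isolated protein for inhibition of Maltase-glucoamylase (Homo sapiens) (on this read-out lower numbers stand for stronger inhibition and higher numbers for weaker inhibition), compound 3 gives 113000 nM, the second highest of the three numbers. Compound 2 gives 107000 nM, which lies within the scatter of the value of compound 3, so no order can be read between them. Compound 1 gives 386000 nM, a higher number that lies beyond the scatter.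

Compound 4 `COc1cc(C(c2c(O)c3cc(Cl)ccc3oc2=O)c2c(O)c3cc(Cl)ccc3oc2=O)ccc1O` differs from compound 3 in one place: 4-hydroxy-3-methoxyphenyl in place of 3-hydroxy-4-methoxyphenyl on a saturated chain carbon bound to two aromatic carbons. Among the compounds with values here, the only measured step, a 3.6-fold lower number from compound 1 to compound 2 (0.56 log units; beyond the scatter), concerns a different change on the same carbon, the replacement of a trimethoxyphenyl by a methoxyphenyl, and so does not bear directly on an exchange of the positions of hydroxy and methoxy. Within the data shown here, no measured pair shows what such an exchange does. With nothing pointing either way, the expected step in this assay is a 1.0-fold lower number from compound 3 to compound 4 (0.01 log units; within the scatter), that is, none beyond the scatter. Compound 4 is therefore estimated at 110000 nM, with a range from 45000 nM to 270000 nM.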

Compound 4, half-maximal inhibitory concentration: 83600 nM
Estimate against measurement, compound 4: 1.3-fold (0.12 log units) above; the range from low to high includes it.
By their numbers in this assay, from the lowest: compounds 4, 2 and 3 (each within the scatter of the next); then compound 1.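

In this assay, putting 4-hydroxy-3-methoxyphenyl in place of 3-hydroxy-4-methoxyphenyl on a saturated chain carbon bound to two aromatic carbons gives a 1.4-fold lower number from compound 3 to compound 4 (0.13 log units; within the scatter) and so leaves the two arrangements indistinguishable on this read-out. Within the data shown here, the earlier step at this carbon changed how many methoxy groups the phenyl ring carried, whereas this pair, with the same atoms joined differently, is the first to test the arrangement of hydroxy and methoxy alone. No available evidence accounts for this result.

On these data alone, whether the exchange behaves the same way in compounds carrying methyl rather than chlorine on the shared core remains open. Also open, as far as these compounds go, is what an amine or a carboxylic acid on this phenyl ring, in place of the hydroxy, would do to the inhibition.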